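A few compounds are considered here, and "the series" means these few. Any claim that something is new, unique, unknown or untested is made for them only; others in the source may bear on it.

Compound 1 `Cn1c(-c2ccc(NC(=O)CSc3nc4ccccc4s3)cc2)nc(-c2ccccc2)c1-c1ccccc1` gives 15.3% in a functional assay on HT-29 cells (Homo sapiens) for cytotoxicity, read by MTT assay, with a stated time of 24 h, tested at 1.6 ug/mL; on this read-out lower numbers stand for a weaker effect and higher numbers for a stronger effect at the one concentration tested. Compound 2 `Cn1ccnc1SCC(=O)Nc1ccc(-c2nc(-c3ccccc3)c(-c3ccccc3)n2C)cc1` gives 23.8% in this assay; the step of a number 8.5 percentage points higher from compound 1 to compound 2 (within the scatter) keeps the two values within the scatter of each other, so compound 2 stands among two numbers that cannot be told apart. Compound 3 `Cn1c(-c2ccc(NC(=O)CN3CCN(c4ccccc4)CC3)cc2)nc(-c2ccccc2)c1-c1ccccc1` differs from compound 2 by 4-phenylpiperazin-1-yl in place of (1-methyl-1H-imidazol-2-yl)sulfanyl on a saturated chain carbon bound to a carbonyl carbon. Within the data shown here, the single measured step concerns a change on the sulfur, not this position, so no measured step bears on it directly. Compound 3 is therefore expected to show a step of a number 1.2 percentage points higher from compound 2 to compound 3 (within the scatter), not clearly beyond the scatter. The estimated value of compound 3 in this assay is 25%, ranging from 5% to 50%.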

Compound 3, a percentage reported as activity, at one concentration (the size of the read-out at that concentration, not a potency): 26%
Compound 3: middle estimate off by 1 percentage points, on the low side; low and high end bracket the measured number.
By their numbers in this assay, from the lowest: compounds 1, 2 and 3 (each within the scatter of the next, the first and the last beyond it).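

In this assay, 4-phenylpiperazin-1-yl, which carries no sulfur, can stand on the saturated chain carbon bound to a carbonyl carbon in place of (1-methyl-1H-imidazol-2-yl)sulfanyl with a number 2.2 percentage points higher from compound 2 to compound 3 (within the scatter) as the result, so the two groups cannot be told apart here. Among these compounds, in place of (1,3-benzothiazol-2-yl)sulfanyl, the same group gives a number 10.7 percentage points higher from compound 1 to compound 3 (beyond the scatter) as the first step beyond the scatter, though only a modest one. No measurement at hand explains either step.

Going by these compounds, whether a simple amine or a carboxylic acid would read the same on this carbon remains open. So does the effect of a longer chain, and with only one concentration tested, the potency of all three compounds is also unknown.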